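The compounds below may be only part of what the source reports. "The series", "measured", "known", "first", "only" and "open" are said of these compounds alone.

Compound 1 `CC1=CC[C@H](C(C)(C)NC(=S)N/N=C/c2ccc(F)cc2)CC1`: in a functional assay on MCF7 cells (Homo sapiens) for inhibition, read by sulforhodamine B assay, with a stated time of 48 h (a lower number here means a stronger inhibitor of growth, a higher number a weaker inhibitor of growth), compound 1 gives > 100000 nM, a limit of the assay.
Compound 2 `CC1=CC[C@H](C(C)(C)NC(=S)N/N=C/c2ccc(Cl)cc2)CC1`: in this assay compound 2 gives > 100000 nM, also a limit.
Compound 3 `CC1=CC[C@H](C(C)(C)NC(=S)N/N=C/c2ccco2)CC1`: in this assay compound 3 gives 53700 nM.

Among the measured compounds shown here, compound 3 thus holds the only number among the three; the other two sit at the limit of > 100000 nM in this assay, at which 2 of the 3 values shown sit. Compound 4 `CC1=CC[C@H](C(C)(C)NC(=S)N/N=C/c2ccc[nH]2)CC1` differs from compound 3 by 1H-pyrrol-2-yl in place of furan-2-yl on a carbon with a double bond to nitrogen. The measured steps that touch this position are an at least 1.8-fold lower number from compound 1 to compound 3 (0.27 log units; that floor lies within the scatter) and an at least 1.8-fold lower number from compound 2 to compound 3 (0.27 log units; that floor lies within the scatter), both floors that lie within the scatter and both concern a different exchange. For the measured compounds named here, no measured step swaps furan-2-yl for 1H-pyrrol-2-yl, so no step beyond the scatter is expected. Compound 4 is therefore estimated at 50000 nM, between 15000 nM and 150000 nM, an expected step of a 1.1-fold lower number from compound 3 to compound 4 (0.03 log units; within the scatter).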

Compound 4, concentration for total growth inhibition: 11500 nM
Compound 4: middle estimate off by 4.3-fold (0.64 log units), on the high side, outside the stated range (below it).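

In this assay, among the compounds shown here, this position proves sensitive to a change of one ring atom: 1H-pyrrol-2-yl in place of furan-2-yl gives a 4.7-fold lower number from compound 3 to compound 4 (0.67 log units; beyond the scatter), the first step here with a readable size beyond the scatter. The exchanges of the phenyl groups for 1H-pyrrol-2-yl, an at least 8.6-fold lower number from compound 2 to compound 4 (0.93 log units; beyond the scatter) and an at least 8.6-fold lower number from compound 1 to compound 4 (0.93 log units; beyond the scatter), also clear the scatter, which neither exchange for furan-2-yl did. Both of these are floors resting on limits: the limit of > 100000 nM in this assay, at which 2 of the 4 values shown sit.

From the compounds shown here alone, whether the lower number goes with the ring hydrogen-bond donor stays open. Neither thiophen-2-yl nor 1-methylpyrrol-2-yl stands among the compounds shown.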